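Adding chloro to a hydroxyphenyl hydrazone: expected cytotoxicity

The source may hold more compounds than are shown below. What is called first, only, known or untested is meant among the compounds shown, and "the series" means these compounds.

Three compounds have so far been measured in a functional assay on MCF7 cells (Homo sapiens) for cytotoxicity, read by MTT assay, with a stated time of 48 h; on this read-out lower numbers stand for stronger inhibition and higher numbers for weaker inhibition:

Compound 1, `O=C(CSc1nnc(-c2ccncc2)o1)N/N=C/c1ccccc1`, gives 14600 nM.
Compound 2, `O=C(CSc1nnc(-c2ccncc2)o1)N/N=C/c1ccc(Cl)cc1`, gives 15300 nM.
Compound 3, `O=C(CSc1nnc(-c2ccncc2)o1)N/N=C/c1ccccc1O`, gives 4750 nM.

Compound 3 stands lowest; its step from compound 1, a 3.1-fold lower number from compound 1 to compound 3 (0.49 log units; beyond the scatter), comes with hydroxy in place of hydrogen on an aromatic carbon, and this is also the whole difference between the core of compound 3 and that of compound 1. Compound 4, `O=C(CSc1nnc(-c2ccncc2)o1)N/N=C/c1cc(Cl)ccc1O`, is not yet measured; it differs from compound 3 by chloro in place of hydrogen on an aromatic carbon. The same kind of change was already made from compound 1 to compound 2, (chloro in place of hydrogen on an aromatic carbon), with a step of a 1.0-fold higher number from compound 1 to compound 2 (0.02 log units; within the scatter). The places are not identical: in compound 2 the chloro sits para to a large group, in compound 4 meta to a large group and para to a hydroxy group. Because the earlier chloro step a 1.0-fold higher number from compound 1 to compound 2 (0.02 log units; within the scatter) stayed within the scatter, the step to compound 4 is expected to be a 1.1-fold lower number from compound 3 to compound 4 (0.02 log units; within the scatter). Compound 4 is therefore expected to give about 4500 nM, between 2000 nM and 10000 nM.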

Compound 4, half-maximal inhibitory concentration: 5830 nM
For compound 4 the middle estimate is 1.3-fold (0.11 log units) below the measured one, within the range that was stated.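

In this assay, chloro on the 2-hydroxyphenyl group leaves the number within the scatter, a 1.2-fold higher number from compound 3 to compound 4 (0.09 log units; within the scatter), and the same change agrees across the two cores: the same change on two cores in this assay, a 1.0-fold higher number (0.02 log units; within the scatter) from compound 1 to compound 2 and a 1.2-fold higher number (0.09 log units; within the scatter) from compound 3 to compound 4, 1.2-fold (0.07 log units) apart, within the scatter of two such steps. Compound 4 also keeps the lower numbers that go with the hydroxy group, a 2.6-fold lower number from compound 2 to compound 4 (0.42 log units; beyond the scatter) and a 2.5-fold lower number from compound 1 to compound 4 (0.40 log units; beyond the scatter). Among the compounds shown here, this shows that the chloro change carried over between these two cores as a step too small to read, but it does not show the same for other cores or other places on the ring, as only two pairs stand behind it, with the chloro placed differently in each.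

From the compounds shown here alone, it remains open whether an amine in place of the hydroxy group would keep the lower numbers. Whether a methoxy group in place of chloro would also leave the number within the scatter is open too.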